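Alkylamino variation on the chlorotriazine series

A few compounds are considered here, and "the series" means these few. Any claim that something is new, unique, unknown or untested is made for them only; others in the source may bear on it.

Measured compounds:
compound 1, `CC(C)N(c1nc(Cl)nc(N[C@@H](C)c2ccccc2)n1)C(C)C` — 372 nM
compound 2, `CC[C@@H](C)Nc1nc(Cl)nc(N[C@H](C)c2ccccc2)n1` — 8320 nM
compound 3, `CCCN(CC)c1nc(Cl)nc(N[C@H](C)c2ccccc2)n1` — 24500 nM

In an ADME assay on the whole organism for inhibition, with Oryza sativa as the target, with a stated time of 4 days (a lower number here means a stronger inhibitor, a higher number a weaker inhibitor), compound 1 gives the lowest of the three numbers; compound 2 sits well above it, and compound 3 stands furthest away, both gaps beyond the scatter. Among the measured compounds shown here, the only measured step that changes a single group is a 2.9-fold higher number from compound 2 to compound 3 (0.47 log units; beyond the scatter), a modest move to a weaker inhibitor on going from a monoalkylamino to a dialkylamino group on the shared core.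

Compound 4 is `CCCN(C)c1nc(Cl)nc(N[C@@H](C)c2ccccc2)n1`. Compared with compound 1 the change is methyl(propyl)amino in place of diisopropylamino on an aromatic carbon. For the measured compounds named here, no measured pair reproduces this exchange: the step from compound 2 to compound 3 alters the same position but starts from a monoalkylamino group, so it bears on the present step only loosely, and the two other measured compounds differ from compound 1 also elsewhere. Taking that modest step as the nearest guide, a shift toward a higher number in this assay is expected for compound 4, of small to modest size, with wide uncertainty. The estimated step is a 3.2-fold higher number from compound 1 to compound 4 (0.51 log units; beyond the scatter). Compound 4 is therefore expected to give 1200 nM in this assay, within a range from 300 nM to 5000 nM.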

Compound 4, half-maximal inhibitory concentration: 5500 nM
The estimate for compound 4 lay 4.6-fold (0.66 log units) below the measured number; measured number above the stated range.
By their numbers in this assay, from the lowest: compound 1; then compounds 4 and 2 (each within the scatter of the next); then compound 3.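

In this assay, the exchange of diisopropylamino for methyl(propyl)amino gives a 15-fold higher number from compound 1 to compound 4 (1.17 log units; beyond the scatter), a large step between two dialkylamino groups on the shared core. The position therefore responds strongly to the choice of alkyl groups even when the amino nitrogen stays dialkylated, which the earlier 2.9-fold higher number from compound 2 to compound 3 (0.47 log units; beyond the scatter), a modest step that started from a monoalkylamino group, could not show. No measurement here explains the size of this step or why it exceeds the earlier one.

The exchange changes the heavy-atom count and the branching of the alkyl groups together, so the compounds shown do not separate these two differences, and the large step rests on a single pair. Going by these compounds, it remains open whether a group that keeps one branched chain, such as isopropyl(methyl)amino, would give a number closer to that of compound 1 or to that of compound 4, and how a ring amine such as piperidine would behave at this position.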